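Lengthening the Amine Chain of Compound 3

The compounds below may be only part of what the source reports. "The series", "measured", "known", "first", "only" and "open" are said of these compounds alone.

Of the compounds shown here, three have been measured in a functional assay on HT-29 cells (Homo sapiens) for cytotoxicity, read by neutral red uptake, with a stated time of 72 h; a lower number here means a stronger inhibitor, a higher number a weaker inhibitor. Compound 1, `CCCNc1nc(NCCC)c2ccccc2n1`, carries two propylamino groups on its core and gives 18900 nM. Compound 2, `CCCCCNc1nc(NCCCCC)c2ccccc2n1`, carries two pentylamino groups on the same core and gives 3570 nM. Compound 3, `CCNc1nc(SCC)nc2ncccc12`, has a different core bearing an ethylamino group and an ethylthio group; in this assay compound 3 gives 26200 nM. Compound 3 stands at the top of the three numbers shown: compound 1 sits within the scatter of it, while compound 2 lies well away from it, beyond the scatter.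

Compound 4, `CCCCCCCNc1nc(SCC)nc2ncccc12`, differs from compound 3 in one place: pentyl in place of hydrogen on a saturated chain carbon, two bonds along the chain from a nitrogen on an aromatic ring. Going by the values given here, no measured pair here differs by exactly this change, so the size of the step is uncertain. The only related observation is that compound 2, with its longer chains, gives 3570 nM while compound 1 gives 18900 nM, and two compounds are a thin basis. Compound 4 is expected to give a lower number than compound 3, with a step of a 4.4-fold lower number from compound 3 to compound 4 (0.64 log units; beyond the scatter) that goes beyond the scatter but stays modest. The estimate for compound 4 is 6000 nM, ranging from 1800 nM to 20000 nM.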

Compound 4, half-maximal inhibitory concentration: 19900 nM
Compound 4: the middle estimate sits 3.3-fold (0.52 log units) below what was measured; the range from low to high includes it.
By their numbers in this assay, from the lowest: compound 2; then compounds 1, 4 and 3 (each within the scatter of the next).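

Putting pentyl in place of hydrogen on this saturated chain carbon, two bonds along the chain from a nitrogen on an aromatic ring, gives a 1.3-fold lower number from compound 3 to compound 4 (0.12 log units; within the scatter) in this assay, so the numbers for the two compounds cannot be told apart. This is the first pair shown that differs in one place only, and it isolates the effect of this change on this core: here, five added chain carbons produce no step that can be separated from ordinary measurement scatter, so the position accepts a much longer chain without a clear change in the read-out. The result cannot be explained from what is shown, as no measurement here bears on it.

As far as these compounds go, whether a smaller addition such as methyl or ethyl at this same place would read any differently remains open, as does the outcome for a chain ending in an amine or a carboxylic acid. A single step on one core also leaves open whether pentyl at this place would give a similar result on the core of compound 1.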